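The source may report more compounds than this note shows. Statements on the series, on what has been measured and on what is new or still open speak of the compounds shown alone.

Measured compounds in the series:

Compound 1, `Cc1ccc2nc(Nc3nc4ccccc4s3)sc2c1`, in a functional assay on THP-1 cells (Homo sapiens) for cytotoxicity, read by MTT assay, with a stated time of 48 h; on this read-out lower numbers stand for stronger inhibition and higher numbers for weaker inhibition: compound 1 gives 34200 nM.
Compound 3, `Cc1ccc2nc(NC(=S)Nc3ccc(F)cc3)sc2c1`, in this assay: compound 3 gives 36900 nM.
Compound 2, `Cc1ccc2nc(NC(=S)Nc3ccccc3)sc2c1`, in this assay: compound 2 gives > 50000 nM, which is a limit of the assay and not a number.

Where compound 2 stands, then, is known only as a limit; its position relative to compound 1 and compound 3 cannot be fixed beyond that, see (the limit of > 50000 nM in this assay, at which 1 of the 3 values shown sits).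

Compound 4, `Fc1ccc2nc(NC(=S)Nc3ccccc3)sc2c1`, differs from compound 2 by fluoro in place of methyl on an aromatic carbon.

Among the compounds with values here, the only measured step that bears on this change is the one from compound 2 to compound 3, an at least 1.3-fold lower number from compound 2 to compound 3 (0.13 log units; that floor lies within the scatter), which also introduces a fluoro, though on the other ring, and which is itself only a floor because compound 2 is a limit. The swap in compound 4 sits on the fused ring instead and exchanges methyl rather than hydrogen, so that step is a weak guide at best. Nothing in the series shows a fluoro producing a shift beyond the scatter in this assay.

The expectation for compound 4 is therefore no change beyond the scatter, a step of a number no higher from compound 2 to compound 4 (the limit leaves the size open), with a fair chance that the assay again reports only a limit. Compound 4 is estimated at 50000 nM, with a range from 20000 nM to 120000 nM.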

Compound 4, half-maximal inhibitory concentration: 46600 nM
For compound 4 the middle estimate is 1.1-fold (0.03 log units) above the measured one; the range from low to high includes it.
By their numbers in this assay, from the lowest: compounds 1, 3 and 4 (each within the scatter of the next). At a limit, above all of these: compound 2.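

Within the data shown here, at this aromatic carbon of the shared core, fluoro in place of methyl gives a first reading in this assay: compound 4 gives 46600 nM, a number and not a limit. Compound 2 gives > 50000 nM, which is a limit of the assay and not a number. The change therefore reads only as an at least 1.0-fold lower number from compound 2 to compound 4 (0.03 log units; that floor lies within the scatter), which shows no shift beyond the scatter at this position, and its true size stays unfixed because one end of the step is a limit: the limit of > 50000 nM in this assay, at which 1 of the 4 values shown sits.

Whether the position tolerates change more broadly stays open, since methyl and fluoro are the only groups shown there, and a chloro, a methoxy, an amine or a carboxylic acid on the same carbon could still move the number beyond the scatter. Also open, as far as these compounds go, is whether fluoro on this carbon and fluoro on the phenyl ring of the thiourea, taken together in one compound, would give a step that can be read beyond the scatter.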